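The source may report more compounds than this note shows. Statements on the series, on what has been measured and on what is new or still open speak of the compounds shown alone.

Measured so far in a functional assay on MGC-803 cells (Homo sapiens) for inhibition, read by MTT assay, with a stated time of 72 h; a lower number here means a stronger inhibitor, a higher number a weaker inhibitor:
compound 1 `CCc1cccc(NC(=O)CSc2nc(Nc3ccccc3)c3ccccc3n2)c1` — 15800 nM
compound 2 `O=C(CSc1nc(Nc2ccccc2)c2ccccc2n1)Nc1ccc([N+](=O)[O-])cc1` — > 50000 nM, which is a limit of the assay, not a number
compound 3 `C=CC(=O)Nc1cccc(NC(=O)CSc2nc(Nc3cccc([N+](=O)[O-])c3)c3ccccc3n2)c1` — > 50000 nM, again a limit of the assay rather than a number

Compound 3 therefore stands at the edge of what this assay can report; only a limit is known for it, and the limit of > 50000 nM in this assay, at which 2 of the 3 values shown sit, shows that it shares this position with one other compound. Compound 4 `C=CC(=O)Nc1cccc(NC(=O)CSc2nc(Nc3ccc(Cl)c(Cl)c3)c3ccccc3n2)c1` differs from compound 3 by one change: 3,4-dichlorophenyl in place of 3-nitrophenyl on a nitrogen on an aromatic ring. The only measured step among these compounds is an at least 3.1-fold higher number from compound 1 to compound 2 (0.50 log units; beyond the scatter), which concerns the group on the amide-type nitrogen, a different place from the one changed here, so it does not bear directly on the step to compound 4. Going by the values given here, no measured step touches the group on the ring nitrogen. With compound 3 already at a limit and no direct guide, compound 4 is expected to remain a weak inhibitor, with an estimated step of an at least 1.2-fold lower number from compound 3 to compound 4 (0.09 log units; that floor lies within the scatter). The estimate for compound 4 is 40000 nM, within a range from 12000 nM to 100000 nM.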

Compound 4, half-maximal inhibitory concentration: > 50000 nM
Compound 4: no number, only a limit (the forecaster's own chance of this, stated with the estimate: 55%); at least 1.2-fold (0.09 log units) between middle value and limit.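

Compound 4 gives > 50000 nM, a limit of the assay and not a number, and compound 3 also sits at a limit, so no step between them can be read: the limit of > 50000 nM in this assay, at which 3 of the 4 values shown sit.

The compounds shown leave open whether 3,4-dichlorophenyl and 3-nitrophenyl on a nitrogen on an aromatic ring differ at all in this assay.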